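The source may hold more compounds than are shown below. What is called first, only, known or untested is meant among the compounds shown, and "the series" means these compounds.

Within the data shown here, compound 1 `C=CCO/N=C/c1c(N)ncnc1Oc1ccc2[nH]c(C)cc2c1F` holds the lowest of the two numbers so far in a functional assay on A-375 cells (Homo sapiens) for antiproliferative activity; on this read-out lower numbers stand for stronger inhibition and higher numbers for weaker inhibition: compound 1 gives 21 nM. Among the measured compounds shown here, its only measured neighbour is compound 2 `Cc1cc2c(F)c(Oc3ncnc(N)c3/C=N/O)ccc2[nH]1`, which in this assay gives 492 nM; the step of a 23-fold higher number from compound 1 to compound 2 (1.37 log units; beyond the scatter) came with hydrogen in place of allyl on an oxygen. Compound 3 `COCCO/N=C/c1c(N)ncnc1Oc1ccc2[nH]c(C)cc2c1F` has not yet been measured. It differs from compound 1 by methoxymethyl in place of vinyl on a saturated chain carbon bound to an oxygen on an unsaturated carbon. For the measured compounds named here, the single measured step bears on this only at a distance: there the oxygen lost its whole substituent, whereas in compound 3 the oxygen keeps one, allyl becoming 2-methoxyethyl. That compound 2, with hydrogen on that oxygen, sits at 492 nM shows the substituent on the oxygen matters, but nothing measured tells how one substituent on that oxygen compares with another. The step of a 1.4-fold higher number from compound 1 to compound 3 (0.15 log units; within the scatter) is therefore expected to be small, within or near the scatter, with no firm direction. Compound 3 is expected to come in at 30 nM, with a range from 10 nM to 100 nM.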

Compound 3, half-maximal inhibitory concentration: 233 nM
Beside the measured number, compound 3's estimate is 7.8-fold (0.89 log units) below it, and the stated range ends below it.
By their numbers in this assay, from the lowest: compound 1; then compound 3; then compound 2.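

In this assay, the step of an 11-fold higher number from compound 1 to compound 3 (1.05 log units; beyond the scatter) shows that the identity of the substituent on this oxygen matters, not merely its presence: with a substituent kept in place, allyl and 2-methoxyethyl are far apart on this read-out. The step of a 2.1-fold lower number from compound 2 to compound 3 (0.32 log units; beyond the scatter) is only modest, so 2-methoxyethyl on the oxygen stands closer to hydrogen in size of step than to allyl, and the ordering of the three compounds places it in the middle, with allyl giving the lowest number of the set. No measurement is available here that explains why allyl and 2-methoxyethyl part so widely.

The compounds shown leave open whether the higher number goes with the loss of the double bond outside aromatic rings or with the entry of the chain oxygen, as the two changes arrive together in this single step. A propyl group on the same oxygen would separate these two changes, while a propargyl, benzyl or 2-aminoethyl group would show how far the low number of compound 1 extends to other substituents.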